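Furan to Thiophene Swap in a Cytotoxicity Series

This account rests on a few compounds, and the source may have more. Where it says the series, first, only, none or still open, it means among the compounds named here.

Of the compounds shown here, two have been measured so far in an ADME assay on MT2 cells (Homo sapiens) for cytotoxicity, read by MTT assay; on this read-out lower numbers stand for higher toxicity in this test and higher numbers for lower toxicity in this test. Compound 1 `Fc1cccc(F)c1Cc1cnc(Nc2ccc(Oc3cccnc3)c(Cl)c2)o1` gives 16000 nM in this assay. Compound 2 `Clc1cccc(Cl)c1Cc1nnc(Nc2ccc(COCc3ccoc3)cc2)o1` gives 21000 nM in this assay, the higher of the two numbers, though the gap to compound 1 lies within the scatter of repeated measurements, so the two compounds cannot be told apart on these data. Going by the values given here, no other step between measured compounds is available.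

Compound 3 `Clc1cccc(Cl)c1Cc1nnc(Nc2ccc(COCc3ccsc3)cc2)o1` is the next compound to be tested. It differs from compound 2 in one place: thiophen-3-yl in place of furan-3-yl on a saturated chain carbon bound to an oxygen on a saturated carbon. The remainder of the molecule is unchanged.

Among the compounds with values here, with no measured step of this kind to lean on, the account expects no change beyond the scatter, which is what a 1.1-fold lower number from compound 2 to compound 3 (0.04 log units; within the scatter) is meant to say. For compound 3 the estimated value in this assay is 19000 nM, with an expected range from 7000 nM to 50000 nM.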

Compound 3, half-maximal cytotoxic concentration: > 100000 nM
Compound 3: only a limit was reported; the forecaster's own chance of this, stated with the estimate: 15%; middle value at least 5.2-fold (0.72 log units) away from the limit.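

The earlier compounds shown here offered no step at this position, and this result shows that the read-out can respond to a change here: thiophen-3-yl in place of furan-3-yl on a saturated chain carbon bound to an oxygen on a saturated carbon gives an at least 4.7-fold higher number from compound 2 to compound 3 (0.67 log units; beyond the scatter) in this assay. The two groups have the same counts of heavy atoms and hydrogen-bond acceptors, differing in the ring's hetero atom, sulfur in place of oxygen. Compound 3 gives > 100000 nM, which is a limit of the assay and not a number, so the full size of the step remains unknown: the limit of > 100000 nM in this assay, at which 1 of the 3 values shown sits.

The compounds shown leave open whether a phenyl ring or a pyridin-3-yl group at this place would stay closer to compound 2 or to compound 3. They also leave open whether a longer chain carrying the thiophen-3-yl group would give a measurable number.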